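The source may report more compounds than this note shows. Statements on the series, on what has been measured and on what is new or still open speak of the compounds shown alone.

Measured set in a functional assay on the whole organism (strain Swiss albino) for inhibition, with Mus musculus as the target, with a stated time of 0.5 h; on this read-out lower numbers stand for an effect already at smaller amounts and higher numbers for an effect only at larger amounts of compound:
Compound 1 `COc1ccc(-n2c(Nc3nc(-c4ccc([N+](=O)[O-])cc4)cs3)n[nH]c2=S)cc1`: 100 mg/kg
Compound 2 `COc1ccccc1-n1c(Nc2nc(-c3ccc([N+](=O)[O-])cc3)cs2)n[nH]c1=S`: 100 mg/kg
Compound 3 `Cc1ccccc1-n1c(Nc2nc(-c3ccc([N+](=O)[O-])cc3)cs2)n[nH]c1=S`: 100 mg/kg

Compound 3 stands level with compounds 1 and 2 at the digits shown; its nearest neighbour in value is compound 1 and its furthest is compound 2, and both gaps are within the scatter. The steps of no change at the digits printed from compound 1 to compound 2 (within the scatter), no change at the digits printed from compound 1 to compound 3 (within the scatter) and no change at the digits printed from compound 2 to compound 3 (within the scatter) each alter only the aryl group on the aromatic nitrogen, and none of them moves the read-out beyond the scatter.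

Compound 4 `Cc1ccccc1-n1c(Nc2nc(-c3ccc(Cl)cc3)cs2)n[nH]c1=S` is not yet measured. Against compound 3 the difference is chloro in place of nitro on an aromatic carbon. Among the measured compounds shown here, no measured step touches this position: the three steps that exist all vary the other aryl group and are flat. For the measured compounds named here, there is thus no direct precedent for the change from compound 3 to compound 4, and the only guide is a series that sits at a single value throughout. The step of no change at the digits printed from compound 3 to compound 4 (within the scatter) is therefore expected to lie within the scatter. The estimate for compound 4 in this assay is 100 mg/kg, with a range from 50 mg/kg to 200 mg/kg.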

Compound 4, minimum effective dose: 100 mg/kg
For compound 4 middle estimate and measured number coincide at the digits printed; the range from low to high includes it.
By their numbers in this assay, from the lowest: compounds 1, 2, 3 and 4 (each within the scatter of the next).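

Chloro in place of nitro gives no change at the digits printed from compound 3 to compound 4 (within the scatter) in this assay, the first reading at this aromatic carbon, since the earlier steps varied only the aryl group on the aromatic nitrogen. The nitro group is therefore not required to keep the read-out at the level of the series: in this pair, 4-chlorophenyl serves as well as 4-nitrophenyl. Nothing measured on the properties of these groups bears on this result.

From the compounds shown here alone, whether the read-out stays level with other groups at this carbon, such as an amine or a carboxylic acid, remains open. Also open, going by these compounds, is whether chloro gives the same result with 4-methoxyphenyl or 2-methoxyphenyl on the aromatic nitrogen, as this pair carries only 2-methylphenyl there.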